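Swapping the hydroxy group of compound 1

The compounds below may be only part of what the source reports. "The series", "measured", "known", "first", "only" and "open" are said of these compounds alone.

In an ADME assay on BHK-21 cells (Mesocricetus auratus) for cytotoxicity, read by MTT assay (a lower number here means that less compound is tolerated, a higher number that more compound is tolerated), compound 1 (`COc1ccc(-c2nc3cc(/C(C)=N/O)ccc3[nH]2)c(OC)c1`) gives > 100000 nM, which is a limit of the assay and not a number. Compound 2 (`COc1ccc(-c2nc3cc(/C(C)=N/O)ccc3[nH]2)c(OC)c1OC`) gives > 100000 nM, which is also a limit. The evidence therefore amounts to the limit of > 100000 nM in this assay, at which 2 of the 2 values shown sit.

Compound 3 (`COc1ccc(-c2nc3cc(/C(C)=N/NC(N)=S)ccc3[nH]2)c(OC)c1`) keeps the core of compound 1 but changes one place, on a double-bonded nitrogen: the hydroxy leaves and a larger group containing sulfur enters, (a group of 4 heavy atoms (1 carbon, 2 nitrogen, 1 sulfur; no ring) in place of one oxygen atom, on a double-bonded nitrogen).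

For the measured compounds named here, no measured step covers this exchange. Going by the values given here, the only one available is a step that the two limits leave unreadable from compound 1 to compound 2, and it concerns a different change, a methoxy in place of hydrogen on an aromatic carbon. It offers just a weak hint that the core tolerates a change without a readable drop, so the size of the new step remains largely open.

The expected step in this assay is an at least 1.6-fold lower number from compound 1 to compound 3 (0.22 log units; that floor lies within the scatter), a cautious estimate toward less compound being tolerated. Compound 3 is estimated at 60000 nM, with an expected range from 12000 nM to 100000 nM.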

Compound 3, half-maximal cytotoxic concentration: 28000 nM
For compound 3 the middle estimate is 2.1-fold (0.33 log units) above the measured one; low and high end bracket the measured number.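

Putting the larger sulfur-containing group in place of the hydroxy, on a double-bonded nitrogen, gives in this assay an at least 3.5-fold lower number from compound 1 to compound 3 (0.55 log units; beyond the scatter), the only step among these compounds whose size can be read at all, even if only as a minimum. Compound 3 gives 28000 nM, a true number rather than a limit, so this position can carry a change that makes less compound tolerated, whereas the step from compound 1 to compound 2, on an aromatic carbon, cannot be read. Compound 3 is thus the only compound here with a measured number, and the other two stay at the ceiling of the assay: the limit of > 100000 nM in this assay, at which 2 of the 3 values shown sit.

On these data alone, it remains open which part of the entering group matters: the same group with an oxygen atom in place of sulfur, or a simple amine on the double-bonded nitrogen, would help to separate the role of the sulfur from that of the added atoms. As far as these compounds go, it is also open how far the full step reaches, and whether the extra methoxy of compound 2 would alter the number when combined with the new group.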